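Inverting One Stereocentre in the Methylamino Compound

A few compounds are considered here, and "the series" means these few. Any claim that something is new, unique, unknown or untested is made for them only; others in the source may bear on it.

Measured in an in vivo ADME assay on the whole organism (plasma, strain Sprague-Dawley) for pharmacokinetics, with Rattus norvegicus as the target; on this read-out lower numbers stand for slow clearance and higher numbers for fast clearance:
- Compound 1 `C[C@@H](c1ccc(N2CC[C@H](NS(=O)(=O)c3ccc4cc(Cl)ccc4c3)C2=O)c(F)c1)N(C)C` gives 13 mL/min/kg
- Compound 2 `CN[C@H](C)c1ccc(N2CC[C@H](NS(=O)(=O)c3ccc4cc(Cl)ccc4c3)C2=O)c(F)c1` gives 1.6 mL/min/kg

Compound 2 holds the lower of the two numbers. With 1-(methylamino)ethyl in place of 1-(dimethylamino)ethyl on an aromatic carbon, the record shows an 8.1-fold lower number from compound 1 to compound 2 (0.91 log units; beyond the scatter) between the pair.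

Compound 3 `CN[C@@H](C)c1ccc(N2CC[C@H](NS(=O)(=O)c3ccc4cc(Cl)ccc4c3)C2=O)c(F)c1` is the next structure to be read out, and the change is simple to state: the two compounds have the same atoms and bonds and differ only in configuration as drawn: 1 of 2 stereo elements differ; a stereocentre at a saturated chain carbon is drawn R in compound 2 and S in compound 3 in the drawn structures.

Within the data shown here, no measured step changes configuration alone, so the data give no direct size for this one. Among the measured compounds shown here, the single measured step bears on it only indirectly, as a sign that a change in this chain can move the number in this assay by a clear margin. Compound 2 stands at 1.6 mL/min/kg on the low side of the two values, so a rise is expected rather than a further fall, and a smaller one than the measured step. The expected move is a 2.5-fold higher number from compound 2 to compound 3 (0.40 log units; beyond the scatter) as an estimate. For compound 3 the estimated clearance is 4 mL/min/kg with an expected range from 1.3 mL/min/kg to 13 mL/min/kg in this measurement.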

Compound 3, clearance: 3.1 mL/min/kg
Estimate against measurement, compound 3: 1.3-fold (0.11 log units) above, and the stated range covers the measured number.
By their numbers in this assay, from the lowest: compounds 2 and 3 (each within the scatter of the next); then compound 1.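

Inverting this one stereocentre in the methylamino compound moves clearance by no more than the assay can resolve: in this assay, the inversion gives a 1.9-fold higher number from compound 2 to compound 3 (0.29 log units; within the scatter), so the data separate compound 2 and compound 3 by no order. The comparison therefore isolates the configuration at this saturated chain carbon, something the earlier pair could not do: the fact that compounds 2 and 3 differ only in the configuration as drawn The position's earlier sensitivity also survives the inversion, as hydrogen in place of methyl on the amine nitrogen gives a 4.2-fold lower number from compound 1 to compound 3 (0.62 log units; beyond the scatter), so both methylamino compounds stand clear of the dimethylamino compound 1 in this read-out, with configuration making no difference that rises above the scatter.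

What the compounds shown leave open is whether this insensitivity to configuration would hold with other groups on that chain carbon, such as a primary amine, an N-ethyl amine or a hydroxyl group in place of the methylamino group. They also leave open how far the second stereocentre, drawn the same in all three compounds, matters for clearance in this assay.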